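Working notes: hexyl to hydrogen in a cytotoxicity series

The source may report more compounds than this note shows. Statements on the series, on what has been measured and on what is new or still open speak of the compounds shown alone.

Measured in a functional assay on L1210 cells (Mus musculus) for cytotoxicity; on this read-out higher numbers stand for an effect only at larger amounts of compound and lower numbers for an effect already at smaller amounts:
compound 1 `COc1cc(CO)c(OC)c2c1C(=O)C=CC2=O`: 0.062 ug/mL
compound 2 `CCCCCCC(O)c1cc(OC)c2c(c1OC)C(=O)C=CC2=O`: 0.22 ug/mL
compound 3 `CCCCCCCC(O)C1=CC(=O)c2c(OC)ccc(OC)c2C1=O`: 1.04 ug/mL

Compound 3 holds the highest number of the three; compound 2 stands nearest to it, compound 1 furthest. The difference between the core of compound 2 and the core of compound 3 is not broken down here.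

One change is made twice. From compound 2 to compound 1 it is hydrogen in place of hexyl on a saturated chain carbon bound to an aromatic carbon and an oxygen on a saturated carbon and gives a 3.5-fold lower number from compound 2 to compound 1 (0.55 log units; beyond the scatter). From compound 3 to compound 4 `COc1ccc(OC)c2c1C(=O)C=C(C(C)O)C2=O`, not yet measured, it is hydrogen in place of hexyl on a saturated chain carbon, two bonds along the chain from a double-bonded ring carbon and an oxygen on a saturated carbon. The two places are not the same: in the first the chain carbon is bound to an aromatic carbon, in the second it sits two bonds along the chain from a double-bonded ring carbon, so this is the same kind of change rather than the same one.

Because compound 2 to compound 1 gives a 3.5-fold lower number from compound 2 to compound 1 (0.55 log units; beyond the scatter), a step of similar size and direction is expected for compound 4, a 3.0-fold lower number from compound 3 to compound 4 (0.47 log units; beyond the scatter), though the different core leaves the size uncertain. Compound 4 is estimated at 0.35 ug/mL, between 0.12 ug/mL and 1 ug/mL.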

Compound 4, concentration for half-maximal effect: 0.487 ug/mL
Estimate against measurement, compound 4: 1.4-fold (0.14 log units) below; the range from low to high includes it.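

In this assay, hydrogen in place of hexyl on the core of compound 3 gives a 2.1-fold lower number from compound 3 to compound 4 (0.33 log units; beyond the scatter), which runs in the same direction as the step on the other core. Set side by side, the two steps cannot be told apart: the same change on two cores in this assay, a 3.5-fold lower number (0.55 log units; beyond the scatter) from compound 2 to compound 1 and a 2.1-fold lower number (0.33 log units; beyond the scatter) from compound 3 to compound 4, 1.7-fold (0.22 log units) apart, within the scatter of two such steps. The change therefore carries over from one core to the other in direction and in rough size, but this rests on two pairs only, with the chain carbon in a different place on each core, and it shows nothing about why the number drops or about any core beyond these two.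

From the compounds shown here alone, only hexyl and hydrogen are compared at this carbon, so the course of the number across intermediate chains such as propyl remains open. Also open, going by these compounds, is whether a longer chain such as decyl, or a chain ending in an amine or a carboxylic acid, would follow the same direction on both cores.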